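The compounds below may be only part of what the source reports. "The series", "measured", "known", "first", "only" and "open" are said of these compounds alone.

Measured so far in a toxicity assay on MDCK cells (Canis lupus familiaris) for cytotoxicity, read by crystal violet staining, with a stated time of 48 h; a lower number here means that less compound is tolerated, a higher number that more compound is tolerated:
- compound 1, `COCOc1ccc(CN(Cc2ccc(C(C)(C)C)cc2)Cc2cc3cc(C)ccc3[nH]c2=O)cc1`: 6400 nM
- compound 2, `Cc1ccc2[nH]c(=O)c(CN(Cc3ccc(OC(C)C)cc3)Cc3ccc(C(C)(C)C)cc3)cc2c1`: > 5000 nM
- compound 3, `Cc1ccc2[nH]c(=O)c(CN(Cc3ccc(SC(F)(F)F)cc3)Cc3ccc(C(C)(C)C)cc3)cc2c1`: > 5000 nM

Compound 3 `Cc1ccc2[nH]c(=O)c(CN(Cc3ccc(SC(F)(F)F)cc3)Cc3ccc(C(C)(C)C)cc3)cc2c1` sits at a limit of this assay, > 5000 nM, and not at a number. Compound 2 `Cc1ccc2[nH]c(=O)c(CN(Cc3ccc(OC(C)C)cc3)Cc3ccc(C(C)(C)C)cc3)cc2c1` likewise reaches only a limit, > 5000 nM. For the measured compounds named here, compound 1 `COCOc1ccc(CN(Cc2ccc(C(C)(C)C)cc2)Cc2cc3cc(C)ccc3[nH]c2=O)cc1` is the one member of the set with a read number, 6400 nM. The steps among them, a step that the limit leaves unreadable from compound 1 to compound 2, a step that the limit leaves unreadable from compound 1 to compound 3 and a step that the two limits leave unreadable from compound 2 to compound 3, cannot be sized; the limit of > 5000 nM in this assay, at which 2 of the 3 values shown sit, is where two of the three values stand.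

Compound 4 `Cc1ccc2[nH]c(=O)c(CN(Cc3ccc(C(C)(C)C)cc3)C(C)c3ccc(F)cc3)cc2c1` differs from compound 3 by 1-(4-fluorophenyl)ethyl in place of 4-((trifluoromethyl)sulfanyl)benzyl on an amine nitrogen. Going by the values given here, none of the measured steps reaches across a change on the amine nitrogen, and none of them has a readable size, so nothing in this assay speaks for a step beyond the scatter in either direction. Compound 3 and compound 2 both only reach a limit, and compound 1 reads close to it, so the expectation for compound 4 is that this assay again reports a limit rather than a number, with the step that the limit leaves unreadable from compound 3 to compound 4 estimated as small. For compound 4 the estimated value in this assay is 8000 nM, with a range from 3000 nM to 25000 nM.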

Compound 4, half-maximal cytotoxic concentration: > 33000 nM
Compound 4: only a limit was reported; the forecaster's own chance of this, stated with the estimate: 70%; middle value at least 4.1-fold (0.61 log units) from the limit.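

For the compounds shown here, on the amine nitrogen, 1-(4-fluorophenyl)ethyl in place of 4-(methoxymethoxy)benzyl gives the first step of readable size in the set in this assay: an at least 5.1-fold higher number from compound 1 to compound 4 (0.71 log units; beyond the scatter). Going by these compounds alone, this is also the first evidence that a change at this place can move the tolerated concentration beyond the scatter, whereas the earlier steps, all among substituted benzyl groups, could not be sized. As far as these compounds go, compound 4 carries a limit, > 33000 nM, so the full size of this step remains unknown, and the steps to compound 4 from compound 2 and from compound 3 cannot be read.

From the compounds shown here alone, the readings for compound 2 and compound 3 also stop at a limit, so it remains open whether either of them would differ from compound 4 in this assay: the limit of > 5000 nM in this assay, at which 2 of the 4 values shown sit. Also open is how this assay would read for an unsubstituted 1-phenylethyl group or a benzyl group carrying a carboxylic acid on the same amine nitrogen, which would help separate the contribution of the fluorine from that of the added methyl branch.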